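A Fluorophenyl Replaces a Pyridinyl at the Ring Nitrogen

The source may report more compounds than this note shows. Statements on the series, on what has been measured and on what is new or still open speak of the compounds shown alone.

Of the compounds shown here, three built on one shared core have been tested in a functional assay on DU-145 cells (Homo sapiens) for cytotoxicity, read by sulforhodamine B assay, with a stated time of 48 h (a higher number here means a weaker inhibitor of growth, a lower number a stronger inhibitor of growth), and none of them has yielded a number. Compound 1 `COc1ccc(CN2CCN(c3nc(Nc4ccc(C#N)c(C(F)(F)F)c4)nc(Oc4ccnc5ccccc45)n3)CC2)c(OC)c1OC` gives only a limit in this assay, > 100000 nM. Compound 2 `N#Cc1ccc(Nc2nc(Oc3ccnc4ccccc34)nc(N3CCN(c4ccccn4)CC3)n2)cc1C(F)(F)F` likewise gives only a limit, > 100000 nM. Compound 3 `N#Cc1ccc(Nc2nc(Oc3ccnc4ccccc34)nc(N3CCN(c4cccc(Cl)c4Cl)CC3)n2)cc1C(F)(F)F` also stops at a limit, > 100000 nM. Compound 2 therefore stands nowhere in particular on the numbers: its value is a limit, and the two other values shown are limits as well, as summed up by the limit of > 100000 nM in this assay, at which 3 of the 3 values shown sit.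

Compound 4 `N#Cc1ccc(Nc2nc(Oc3ccnc4ccccc34)nc(N3CCN(c4ccc(F)cc4)CC3)n2)cc1C(F)(F)F` differs from compound 2 in one place: 4-fluorophenyl in place of pyridin-2-yl on an amine nitrogen in a ring.

Among the compounds with values here, the only measured step that touches the same position is a step that the two limits leave unreadable from compound 2 to compound 3, which exchanges one aromatic substituent on the ring nitrogen for another, and it cannot be read because both ends are limits. Within the data shown here, nothing among the measured compounds suggests that a change at this position brings the value down into the measurable range, so the expected step that the limit leaves unreadable from compound 2 to compound 4 is one that keeps compound 4 at or near the limit. For compound 4 the estimate in this assay is 150000 nM, within a range from 50000 nM to 500000 nM.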

Compound 4, concentration for total growth inhibition: > 100000 nM
Compound 4: a limit, no number; the forecaster's own chance of this, stated with the estimate: 80%; the middle value does not contradict the limit.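

In this assay compound 4 gives > 100000 nM, which is a limit and not a number. The steps to compound 4 from compound 2 and from compound 3 cannot be read. The compounds shown leave open whether any group on this amine nitrogen in a ring brings a value into the measurable range: the limit of > 100000 nM in this assay, at which 4 of the 4 values shown sit.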